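Chloro for bromo in a small antiproliferative series

This account rests on a few compounds, and the source may have more. Where it says the series, first, only, none or still open, it means among the compounds named here.

Compound 1 `COc1ccc(C(=O)/C=C/c2cc(Cl)cc(Cl)c2Oc2c([N+](=O)[O-])cc(C(F)(F)F)cc2[N+](=O)[O-])cc1` gives 12.6 ug/mL
Compound 2 `COc1ccc(C(=O)/C=C/c2cccc(Br)c2Oc2c([N+](=O)[O-])cc(C(F)(F)F)cc2[N+](=O)[O-])cc1` gives 12.7 ug/mL

Going by the values given here, only two numbers are available so far. In a functional assay on A549 cells (Homo sapiens) for antiproliferative activity, read by MTT assay, with a stated time of 48 h (on this read-out higher numbers stand for weaker inhibition and lower numbers for stronger inhibition), compound 2 gives 12.7 ug/mL and sits level with compound 1 (12.6 ug/mL), as the two values lie within the usual scatter of repeated measurements.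

Compound 3 `COc1ccc(C(=O)/C=C/c2cccc(Cl)c2Oc2c([N+](=O)[O-])cc(C(F)(F)F)cc2[N+](=O)[O-])cc1` has not yet been measured. It differs from compound 2 in one place (chloro in place of bromo on an aromatic carbon): chloro in place of bromo on an aromatic carbon, ortho to a large group and meta to a 2-((4-methoxyphenyl)carbonyl)ethenyl group. Among the compounds with values here, no measured pair shows this swap on its own, so the data give no direct guide to its size. With just two close values to go on, no step beyond the scatter is expected in this assay in either direction. The expected change (a 1.1-fold lower number from compound 2 to compound 3 (0.02 log units; within the scatter)) is therefore estimated to be small. For compound 3 the estimated value is 12 ug/mL with an expected range from 5.5 ug/mL to 26 ug/mL on measurement.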

Compound 3, half-maximal inhibitory concentration: 11.5 ug/mL
Compound 3: the middle estimate sits 1.0-fold (0.02 log units) above what was measured, within the range that was stated.
By their numbers in this assay, from the lowest: compounds 3, 1 and 2 (each within the scatter of the next).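

In this assay, the change of bromo to chloro on this aromatic carbon, ortho to a large group and meta to a 2-((4-methoxyphenyl)carbonyl)ethenyl group, can now be read directly: a 1.1-fold lower number from compound 2 to compound 3 (0.04 log units; within the scatter), so the assay does not tell these two groups apart here. Going by these compounds alone, the new compound also allows a second direct comparison, as compound 1 carries a further chloro on an aromatic carbon where compound 3 has hydrogen: a 1.1-fold lower number from compound 1 to compound 3 (0.04 log units; within the scatter), so removing that chloro gives no step that can be told from the scatter either. No other measurement on these compounds bears on this result.

On these data alone, all three compounds carry a halogen on the carbon where bromo and chloro were exchanged, so it stays open whether hydrogen, a methoxy group or an amine at that place would move the number beyond the scatter. As far as these compounds go, it also stays open whether a larger change elsewhere, such as a nitrile or a carboxylic acid in place of one of the nitro groups, would produce a step that these small halogen changes do not.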